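A few compounds are considered here, and "the series" means these few. Any claim that something is new, unique, unknown or untested is made for them only; others in the source may bear on it.

Measured compounds and their values in an in vivo ADME assay on the whole organism for pharmacokinetics, at a dose of 0.5 mg/kg by the intravenous route; on this read-out higher numbers stand for wider distribution into tissues and lower numbers for narrower distribution:

- compound 1, `Cn1nc(-c2cccc(C#N)c2)s/c1=N\c1cccc(C(=O)O)c1`: 0.99 L/kg
- compound 2, `Cn1nc(-c2ccc(C(N)=O)cc2)s/c1=N\C1CCCC(O)C1`: 1.39 L/kg; 1.78 L/kg (2 entries)
- compound 3, `Cn1nc(-c2ccc(C(N)=O)cc2)s/c1=N\C1CCCCC1`: 7.65 L/kg

Of the numbers shown, compound 3 stands highest in this assay. Compound 1 gives a clearly lower number, a gap well beyond the scatter of repeated measurements. Compound 2 does not have a single number; its several entries are the several entries of compound 2 in this assay, 1.39 L/kg; 1.78 L/kg (2 entries), and both of them sit far below the number of compound 3.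

The step now followed leads from compound 3 to compound 4, `Cn1nc(-c2ccc(C(N)=O)cc2)s/c1=N\C1CCC(O)CC1`, which has not yet been measured in this assay. The change is hydroxy in place of hydrogen on a saturated ring carbon.

Among the compounds with values here, no measured pair differs in exactly this way, so the expectation rests on the neighbouring compounds. Compound 2 also carries a hydroxy group on its saturated ring, and it gives only (the several entries of compound 2 in this assay, 1.39 L/kg; 1.78 L/kg (2 entries)), far below compound 3. For that reason compound 4 is expected to fall well below compound 3, a step of a 4.3-fold lower number from compound 3 to compound 4 (0.63 log units; beyond the scatter), beyond the scatter. The estimate for compound 4 in this assay is 1.8 L/kg, in the range from 0.9 L/kg to 4 L/kg.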

Compound 4, volume of distribution: 0.98 L/kg
For compound 4 the middle estimate is 1.8-fold (0.26 log units) above the measured one, within the range that was stated.
By their numbers in this assay, from the lowest: compounds 4 and 1 (each within the scatter of the next); then compound 3.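

In this assay, within the data shown here, this is the first pair that isolates the change, and it gives a 7.8-fold lower number from compound 3 to compound 4 (0.89 log units; beyond the scatter). Going from cyclohexyl to 4-hydroxycyclohexyl is therefore enough on its own to move the read-out towards narrower distribution into tissues, something no earlier pair could show. Here the hydroxy group sits three ring bonds from the ring atom that bears a large group, while compound 2 carries its hydroxy group on a different carbon of the same ring, with these numbers: the several entries of compound 2 in this assay, 1.39 L/kg; 1.78 L/kg (2 entries)

The compounds shown leave open whether an amine or a carboxylic acid on the same ring carbon would act like the hydroxy group. They also leave open whether a longer chain ending in a hydroxy group, such as hydroxymethyl or hydroxyethyl, would give a similar number.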